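Extending the Amine Substituent on a Second Core

The source may report more compounds than this note shows. Statements on the series, on what has been measured and on what is new or still open speak of the compounds shown alone.

Compound 1 `CNCC(=O)Nc1cc(OC)ccc1C(=O)c1cc(OC)c(OC)c(OC)c1` and compound 2 `CCNCC(=O)Nc1cc(OC)ccc1C(=O)c1cc(OC)c(OC)c(OC)c1` share one core and differ by methyl in place of hydrogen on a saturated chain carbon bound to an amine nitrogen. In a functional assay on HCT-8 cells (Homo sapiens) for antiproliferative activity, read by MTT assay, with a stated time of 48 h (a higher number here means a weaker inhibitor, a lower number a stronger inhibitor), compound 1 gives 780 nM, and compound 2 gives 1560 nM; the step is a 2.0-fold higher number from compound 1 to compound 2 (0.30 log units; within the scatter). Compound 3 `C=C(c1ccc(OC)cc1NC(=O)CNC)c1ccc(OC)c2c1OC(C)(C)C=C2` is built on a different core, and the difference between the two cores is not broken down here. In this assay compound 3 gives 320 nM, the lowest of the three numbers, with its gaps to compound 1 and to compound 2 both beyond the scatter. Compound 4 `C=C(c1ccc(OC)cc1NC(=O)CNCC)c1ccc(OC)c2c1OC(C)(C)C=C2` has not yet been measured. It differs from compound 3 by methyl in place of hydrogen on a saturated chain carbon bound to an amine nitrogen, the same change already made from compound 1 to compound 2, so the change occurs twice among these compounds. Among the measured compounds shown here, the step in this assay from compound 3 to compound 4 is expected to be of similar size, a 1.9-fold higher number from compound 3 to compound 4 (0.27 log units; within the scatter), because a 2.0-fold higher number from compound 1 to compound 2 (0.30 log units; within the scatter) is the only measured instance of this change. On that basis compound 4 is expected to give about 600 nM, with a likely range from 250 nM to 1500 nM.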

Compound 4, half-maximal inhibitory concentration: 1380 nM
Estimate against measurement, compound 4: 2.3-fold (0.36 log units) below, and the stated range covers the measured number.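

In this assay the methyl in place of hydrogen on a saturated chain carbon bound to an amine nitrogen, carried to the second core, gives a step beyond the scatter (a 4.3-fold higher number from compound 3 to compound 4 (0.63 log units; beyond the scatter)), whereas the same change on the first core stays within it. Set side by side, the two steps cannot be told apart: the same change on two cores in this assay, a 2.0-fold higher number (0.30 log units; within the scatter) from compound 1 to compound 2 and a 4.3-fold higher number (0.63 log units; beyond the scatter) from compound 3 to compound 4, 2.2-fold (0.33 log units) apart, within the scatter of two such steps. Among the compounds shown here, this shows that the size of the step on the second core is compatible with the size on the first, so no dependence on the core can be claimed, but with only one pair on each core it does not show that the change has the same effect on both, nor that it would hold on any further core.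

The compounds shown leave open how a longer chain, such as propylamino or butylamino, would read in this assay in place of ethylamino on either core. They also leave open what a cyclic amine such as pyrrolidine, or a hydroxyl group in place of the amine, would give.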